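Swapping the Amide Linker for a Hydroxypyrrolidine Ring

The source may hold more compounds than are shown below. What is called first, only, known or untested is meant among the compounds shown, and "the series" means these compounds.

The series rests on a shared core, seen first in compound 1 `CCCCCCCCc1ccc(NC(=O)[C@@H](N)CO)cc1`. In an assay on isolated protein for inhibition of sphingosine kinase 1 (Homo sapiens), read by mobility shift assay (a higher number here means a weaker inhibitor, a lower number a stronger inhibitor), compound 1 gives 4300 nM. Compound 2 `CCCCCCCCc1ccc(NC(=O)[C@H](N)[C@@H](C)O)cc1` alters the side chain on the carbonyl carbon; in this assay compound 2 gives 1600 nM, and the step of a 2.7-fold lower number from compound 1 to compound 2 (0.43 log units; beyond the scatter) is modest but beyond the scatter. Within the data shown here, compound 2 thus holds the lowest of the two numbers so far, with compound 1 as its only neighbour. Compound 3 `CCCCCCCCc1ccc(NC[C@H]2NCC[C@@H]2O)cc1` departs more sharply: (3-hydroxypyrrolidin-2-yl)methyl in place of (1-amino-2-hydroxypropyl)carbonyl on a nitrogen on an aromatic ring. Among the measured compounds shown here, no measured step covers an exchange of this kind; the single step in hand, a 2.7-fold lower number from compound 1 to compound 2 (0.43 log units; beyond the scatter), touches only the hydroxy-bearing side chain and leaves the amide in place, so it offers little guidance beyond showing that changes in this region move the number modestly. The expectation for compound 3 is therefore broad and centred near no change, a 1.1-fold lower number from compound 2 to compound 3 (0.03 log units; within the scatter). Compound 3 is estimated at 1500 nM, within a range from 300 nM to 8000 nM.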

Compound 3, half-maximal inhibitory concentration: 740 nM
Compound 3: middle estimate off by 2.0-fold (0.31 log units), on the high side, within the range that was stated.
By their numbers in this assay, from the lowest: compound 3; then compound 2; then compound 1.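

The result shows that this position tolerates more than a change in the side chain: the carbonyl can be lost and a five-membered non-aromatic ring introduced, and the number still falls, with a 2.2-fold lower number from compound 2 to compound 3 (0.33 log units; beyond the scatter). Among these compounds, measured against the first compound of the series in this assay, the same group gives a 5.8-fold lower number from compound 1 to compound 3 (0.76 log units; beyond the scatter), so (3-hydroxypyrrolidin-2-yl)methyl is the best replacement on the nitrogen on the aromatic ring among the three compounds. No supporting evidence bears on why the number falls.

The exchange removes the carbonyl and closes the ring in one step, so the compounds shown do not separate the two changes. They also leave open whether a six-membered piperidine ring, a carboxylic acid in place of the hydroxy group, or other stereoisomers of the ring would keep this gain.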